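The source may hold more compounds than are shown below. What is called first, only, known or untested is meant among the compounds shown, and "the series" means these compounds.

Among the measured compounds shown here, compound 2 `CCCS(=O)(=O)Nc1ccc(F)c(C(=O)c2n[nH]c3ncc(-c4ccc(C(C)(C)C)cc4)cc23)c1F` is one of two compounds measured so far in an assay for binding affinity to dual specificity mitogen-activated protein kinase kinase 4 (Homo sapiens), read by KINOMEscan, tested at 100 nM; a lower number here means a stronger effect, a higher number a weaker effect of the compound at the concentration tested. In this assay compound 2 gives 46%, the highest of the two numbers, meaning the weaker of the two effects at the concentration tested. Its nearest neighbour is compound 1 `CCCS(=O)(=O)Nc1ccc(F)c(C(=O)c2n[nH]c3ncc(-c4cccc(F)c4)cc23)c1F`, which in this assay gives 8.2%. For the measured compounds named here, the single measured step, a number 37.8 percentage points higher from compound 1 to compound 2 (beyond the scatter), is the only comparison available, and it lies beyond the scatter. Compound 3 `CCCS(=O)(=O)Nc1ccc(F)c(C(=O)c2n[nH]c3ncc(-c4ccc(S(N)(=O)=O)cc4)cc23)c1F` has not been measured. It differs from compound 2 in one place: sulfamoyl in place of tert-butyl on an aromatic carbon. Going by the values given here, no measured step shows sulfamoyl entering or tert-butyl leaving. The step from compound 1 to compound 2 only shows that exchanging the group at this place can move the number a long way; it does not show which way a sulfamoyl would move it. A moderate step back toward the smaller numbers is therefore expected, a number 16 percentage points lower from compound 2 to compound 3 (beyond the scatter), with wide uncertainty around it. Compound 3 is expected to give about 30% in this assay, somewhere between 8% and 65%.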

Compound 3, a percentage reported as activity, at one concentration (the size of the read-out at that concentration, not a potency): 0.25%
Beside the measured number, compound 3's estimate is 29.8 percentage points above it; the whole stated range lies above it.
By their numbers in this assay, from the lowest: compounds 3 and 1 (each within the scatter of the next); then compound 2.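

In this assay, the step of a number 45.8 percentage points lower from compound 2 to compound 3 (beyond the scatter) is large, although tert-butyl and sulfamoyl each hold 4 heavy atoms, so the count of heavy atoms at this place does not by itself set the number. The step of a number 8 percentage points lower from compound 1 to compound 3 (within the scatter) shows that compound 3 cannot be told apart from compound 1 even though their aromatic groups differ, which means that among these three compounds only the 4-(tert-butyl)phenyl of compound 2 stands apart with a higher number. Nothing available here explains the gap between tert-butyl and sulfamoyl.

The compounds shown leave open whether tert-butyl is an isolated case or whether other groups at this place, such as a carboxylic acid, an amine or a longer alkyl chain, would also give a high number. They also leave open how sulfamoyl would behave elsewhere on the ring, and what its effect would be on any target other than the one tested here.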